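The source may hold more compounds than are shown below. What is called first, only, known or untested is meant among the compounds shown, and "the series" means these compounds.

Measured compounds in a functional assay on HeLa cells (Homo sapiens) for inhibition, read by MTT assay, with a stated time of 24 h; on this read-out lower numbers stand for stronger inhibition and higher numbers for weaker inhibition:
Compound 1 `CCOC(=O)C1=Cc2ccccc2OC1(OCc1cc(-c2ccc(F)cc2F)no1)C(F)(F)F` gives > 150000 nM, which is a limit of the assay rather than a number.
Compound 2 `O=C(O)C1=Cc2ccccc2OC1(OCc1cc(-c2ccc(F)cc2F)no1)C(F)(F)F` gives > 150000 nM, again only a limit.
Compound 3 `O=C(O)C1=Cc2ccccc2OC1(OCc1cc(-c2cccc(C(F)(F)F)c2)no1)C(F)(F)F` gives > 150000 nM, also a limit.

Compound 1 therefore stands at the limit of > 150000 nM in this assay, at which 3 of the 3 values shown sit, and nothing on the shown numbers separates it from the other two. The step that the two limits leave unreadable from compound 1 to compound 2, hydrogen in place of ethyl on an oxygen next to a carbonyl group, cannot be sized, and the same holds for a step that the two limits leave unreadable from compound 2 to compound 3, 3-(trifluoromethyl)phenyl in place of 2,4-difluorophenyl on an aromatic carbon.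

Compound 4 `CCOC(=O)C1=Cc2ccccc2OC1(OCc1cc(-c2ccc(F)cc2)no1)C(F)(F)F` differs from compound 1 by hydrogen in place of fluoro on an aromatic carbon. Neither measured step bears directly on this change; both stay at the limit, so no size in either direction can be read from them. Within the data shown here, with every value so far at the limit, the expectation is that compound 4 also shows no activity beyond the scatter. The step expected is a step that the limit leaves unreadable from compound 1 to compound 4. Compound 4 is expected to give about 200000 nM in this assay, with an estimated range from 100000 nM to 500000 nM.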

Compound 4, half-maximal inhibitory concentration: 42300 nM
Compound 4: the middle estimate sits 4.7-fold (0.67 log units) above what was measured, outside the stated range (below it).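

In this assay, among these compounds, the change from 2,4-difluorophenyl to 4-fluorophenyl is the first in this set that can be sized: hydrogen in place of fluoro on an aromatic carbon gives an at least 3.5-fold lower number from compound 1 to compound 4 (0.54 log units; beyond the scatter). Among the compounds shown here, this shows that on this aromatic carbon, ortho to a large group and meta to a fluoro group, a single change of atom can move the read-out beyond the scatter, which the earlier steps could not show, as none of them can be read. Compound 4 is the only compound shown with a number, and the others stay at a limit: the limit of > 150000 nM in this assay, at which 3 of the 4 values shown sit.

From the compounds shown here alone, the full size of the step stays open, as compound 1 is known only as a limit. Also open, going by these compounds, are whether a carboxylic acid in place of the ethyl ester of compound 4 would keep its number, and what a chloro or methoxy group on that same aromatic carbon would give.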